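Swapping the ring on an inactive carbamate chain

The compounds below may be only part of what the source reports. "The series", "measured", "known", "first", "only" and "open" are said of these compounds alone.

Measured in a functional assay on the whole organism for agonist activity, with Mus musculus as the target; on this read-out lower numbers stand for an effect already at smaller amounts and higher numbers for an effect only at larger amounts of compound:
- Compound 1 `COC(=O)N(C)C(C)C#CCn1cncc1C`: > 100 mg/kg
- Compound 2 `CCOC(=O)N(C)CC#CCn1cncc1C`: > 100 mg/kg
- Compound 3 `CCOC(=O)N(C)C(C)C#CCN1CCCC1`: > 100 mg/kg

Within the data shown here, the whole series so far comes down to one entry: the limit of > 100 mg/kg in this assay, at which 3 of the 3 values shown sit. Compound 3 stands at > 100 mg/kg, which is a limit of the assay and not a number. No exact dose is therefore known for any of these compounds, and no size of step can be read between them.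

Compound 4 `CCOC(=O)N(C)C(C)C#CCn1cncc1C` keeps the rest of compound 3 and carries 5-methyl-1H-imidazol-1-yl in place of pyrrolidin-1-yl on a saturated chain carbon bound to a triple-bonded carbon.

That entering group is not new to the series. Compound 1 already carries it and gives > 100 mg/kg, also a limit. Compound 2 carries it as well and gives > 100 mg/kg, again a limit. On this basis, compound 4 is expected to stay at the limit in this assay, with no gain in potency. The estimated step that the limit leaves unreadable from compound 3 to compound 4 is expected to lie within the usual scatter. For compound 4 the estimated value is 130 mg/kg, with an expected range from 50 mg/kg to 300 mg/kg.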

Compound 4, dose for half-maximal effect: > 100 mg/kg
Compound 4: no number, only a limit (the forecaster's own chance of this, stated with the estimate: 80%); the middle value does not contradict the limit.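

Compound 4 gives > 100 mg/kg in this assay and that is a limit, not a number. No step can be read between compound 4 and compound 1, compound 2 or compound 3, because all of them share one entry: the limit of > 100 mg/kg in this assay, at which 4 of the 4 values shown sit.

The compounds shown leave open at what dose, if any, each of them would produce an effect.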